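This account rests on a few compounds, and the source may have more. Where it says the series, first, only, none or still open, it means among the compounds named here.

Compound 1 `CCCNc1cc(Oc2ccc(NC(=O)Nc3cccc(C(F)(F)F)c3)cc2)ncn1` is a urea built on a shared core with a propylamino group. For the measured compounds named here, in an assay on isolated protein for inhibition of serine/threonine-protein kinase TNNI3K (Homo sapiens) (on this read-out higher numbers stand for weaker inhibition and lower numbers for stronger inhibition), compound 1 gives 32 nM, the lowest of the three numbers measured so far. Compound 3 `CNc1cc(Oc2ccc(NC(=O)Nc3cccc(C(F)(F)F)c3)c(F)c2)ncn1` gives 63 nM, a value that lies within the usual scatter of that of compound 1, so the two cannot be ordered. Compound 2 `CNc1cc(Oc2ccc(NC(=O)Nc3cccc(C(F)F)c3)cc2)ncn1` gives 100 nM, which stands beyond the scatter above compound 1; compound 2 differs from compound 1 in more than one place, so the two values are reported side by side without a single step between them.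

Compound 4 `C[C@@H](O)CNc1cc(Oc2ccc(NC(=O)Nc3cccc(C(F)(F)F)c3)cc2)ncn1` is the next compound to be measured. It differs from compound 1 in one place: hydroxy in place of hydrogen on a saturated chain carbon bound to two saturated chain carbons. Going by the values given here, no measured pair shows this change, so what follows is an expectation only. The change adds a hydroxy group to the chain while leaving the urea and the shared core untouched, and the three measured compounds give no ground for a large shift in either direction. Compound 4 is therefore expected to land close to compound 1, with a step of a 1.1-fold lower number from compound 1 to compound 4 (0.03 log units; within the scatter) that stays within the scatter. Compound 4 is estimated at 30 nM, in a range from 12 nM to 80 nM.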

Compound 4, half-maximal inhibitory concentration: 63 nM
Compound 4: the middle estimate sits 2.1-fold (0.32 log units) below what was measured, within the range that was stated.
By their numbers in this assay, from the lowest: compounds 1, 3, 4 and 2 (each within the scatter of the next, the first and the last beyond it).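

For the compounds shown here, the comparison of compound 1 with compound 4 is the first that isolates one change, propylamino to (2-hydroxypropyl)amino, which in this assay gives a 2.0-fold higher number from compound 1 to compound 4 (0.29 log units; within the scatter). Going by these compounds alone, the two compounds therefore cannot be ordered, and the earlier compounds, none of which formed a one-place pair, could not show that this chain accepts hydroxy in place of hydrogen, on a saturated chain carbon bound to two saturated chain carbons, without a step beyond the scatter. No measurement is available that bears on why the step has this size.

The compounds shown rest on this single pair, so they leave open whether the same change would give a similar step with a different urea partner, such as the difluoromethyl urea of compound 2, or on the core of compound 3. They also leave open how this chain would read with the opposite configuration at the hydroxy-bearing carbon, or with an amine, a carboxylic acid or a longer chain carrying the hydroxy group in its place.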